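Does a chloro help the phenyl compound too?

The compounds below may be only part of what the source reports. "The series", "measured", "known", "first", "only" and "open" are said of these compounds alone.

In a functional assay on OVCAR-8 cells (Homo sapiens) for inhibition, read by sulforhodamine B assay, with a stated time of 48 h (a lower number here means a stronger inhibitor of growth, a higher number a weaker inhibitor of growth), compound 3 `N#Cc1c(-c2nnc(-c3ccccc3)c3nn(-c4ccccc4)cc23)nn(-c2ccccc2)c1-c1ccccc1` gives 68000 nM and compound 1 `N#Cc1c(-c2nnc(O)c3nn(-c4ccccc4)cc23)nn(-c2ccccc2)c1-c1ccccc1` gives 61500 nM with a 1.1-fold higher number from compound 1 to compound 3 (0.04 log units; within the scatter) between them, so the two sit level. Compound 2 `N#Cc1c(-c2nnc(O)c3nn(-c4ccc(Cl)cc4)cc23)nn(-c2ccccc2)c1-c1ccccc1` gives 3230 nM and lies well below both. Compound 4 `N#Cc1c(-c2nnc(-c3ccccc3)c3nn(-c4ccc(Cl)cc4)cc23)nn(-c2ccccc2)c1-c1ccccc1` turns the phenyl of compound 3 into 4-chlorophenyl, chloro in place of hydrogen on an aromatic carbon, para to a large group (chloro in place of hydrogen on an aromatic carbon). The same change was measured in one other pair, giving a 19-fold lower number from compound 1 to compound 2 (1.28 log units; beyond the scatter) as a large step. That single case is thin support, so a smaller step in the same direction is expected. Expected in this assay is an 8.5-fold lower number from compound 3 to compound 4 (0.93 log units; beyond the scatter) as an estimate. Compound 4 is expected at 8000 nM within 2000 nM to 35000 nM for most repeat measurements.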

Compound 4, concentration for 50% growth inhibition: 9230 nM
Compound 4: the middle estimate sits 1.2-fold (0.06 log units) below what was measured; the measured number falls inside the stated range.
By their numbers in this assay, from the lowest: compound 2; then compound 4; then compounds 1 and 3 (each within the scatter of the next).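

The chloro change now lowers the number on a second core, with a 7.4-fold lower number from compound 3 to compound 4 (0.87 log units; beyond the scatter), so the gain is not confined to the hydroxy compounds, and its size agrees across the two cores within the scatter: the same change on two cores in this assay, a 19-fold lower number (1.28 log units; beyond the scatter) from compound 1 to compound 2 and a 7.4-fold lower number (0.87 log units; beyond the scatter) from compound 3 to compound 4, 2.6-fold (0.41 log units) apart, within the scatter of two such steps. Phenyl in place of hydroxy, level without the chloro, gives a 2.9-fold higher number from compound 2 to compound 4 (0.46 log units; beyond the scatter) with it, though the two steps again agree within the scatter: the same change on two cores in this assay, a 1.1-fold higher number (0.04 log units; within the scatter) from compound 1 to compound 3 and a 2.9-fold higher number (0.46 log units; beyond the scatter) from compound 2 to compound 4, 2.6-fold (0.41 log units) apart, within the scatter of two such steps.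

Open, from the compounds shown here alone, is whether fluoro, methoxy or an amine on that same carbon would lower the number as chloro does.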